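Chloro to fluoro on the aryl group of compound 1

A few compounds are considered here, and "the series" means these few. Any claim that something is new, unique, unknown or untested is made for them only; others in the source may bear on it.

Within the data shown here, compound 1 `Fc1cc(Cl)ccc1N1CCN(Cc2ccn3c(CC4CC4)nnc3c2C(F)(F)F)CC1` is tested in a functional assay on HEK293 cells for agonist activity at metabotropic glutamate receptor 2 (Homo sapiens), read by a luciferase reporter and cAMP accumulation (a lower number here means that less compound is needed, a higher number that more compound is needed for the effect), and gives 7280 nM, the higher of the two numbers known so far. Compound 2 `Fc1ccc(C2CCN(Cc3ccn4c(CC5CC5)nnc4c3C(F)(F)F)CC2)c(F)c1` gives in this assay 371 nM, a lower number beyond the scatter. Compound 3 `Fc1ccc(N2CCN(Cc3ccn4c(CC5CC5)nnc4c3C(F)(F)F)CC2)c(F)c1` is not yet measured; it differs from compound 1 in one place, (fluoro in place of chloro on an aromatic carbon). Among the measured compounds shown here, no directly comparable step is known, so only a modest move downward is expected, from compound 1 to compound 3 of a 2.1-fold lower number from compound 1 to compound 3 (0.32 log units; beyond the scatter). For compound 3 the estimate in this assay is 3500 nM, within 900 nM to 13000 nM.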

Compound 3, half-maximal effective concentration: 82 nM
For compound 3 the middle estimate is 43-fold (1.63 log units) above the measured one, outside the stated range (below it).
By their numbers in this assay, from the lowest: compound 3; then compound 2; then compound 1.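

In this assay, fluoro in place of chloro on the aromatic carbon para to a large group gives an 89-fold lower number from compound 1 to compound 3 (1.95 log units; beyond the scatter). Among these compounds, this is the first single-place comparison, and it shows that the number is highly sensitive to this one atom, even though the change from 4-chloro-2-fluorophenyl to 2,4-difluorophenyl leaves the counts of donors and acceptors unchanged. Nothing available accounts for the size of this step. Going by these compounds, whether a methyl, a methoxy or a nitrile at this carbon would give a lower or higher number remains open. So does whether a step of this size would recur on the aryl group of compound 2.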